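Swapping bromo for methyl on the cytotoxic compound 2

The source may report more compounds than this note shows. Statements on the series, on what has been measured and on what is new or still open speak of the compounds shown alone.

Measured in a functional assay on PC-3 cells (Homo sapiens) for cytotoxicity, read by MTT assay, with a stated time of 72 h; a higher number here means a weaker inhibitor, a lower number a stronger inhibitor:
- compound 1 `Cc1ccc(S(=O)(=O)n2cc(COC3=C/C(=N\c4ccc(I)cc4)c4ccccc4C3=O)nn2)cc1`: > 16300 nM (a limit of the assay, not a number)
- compound 2 `Cc1ccc(S(=O)(=O)n2cc(COC3=C/C(=N\c4ccc(Br)cc4)c4ccccc4C3=O)nn2)cc1`: 3410 nM

Going by the values given here, compound 2, at 3410 nM, holds the only exact number in this assay. Compound 3 `Cc1ccc(/N=C2\C=C(OCc3cn(S(=O)(=O)c4ccc(C)cc4)nn3)C(=O)c3ccccc32)cc1` differs from it by one change, methyl in place of bromo on an aromatic carbon. Among the compounds with values here, the only measured step that bears on this is an at least 4.7-fold lower number from compound 1 to compound 2 (0.67 log units; beyond the scatter), which lies beyond the scatter. It swapped iodo for bromo, so it shows that this group can matter but gives no direction for methyl. No clear shift beyond the scatter is therefore expected, and the estimated change is a 1.3-fold higher number from compound 2 to compound 3 (0.12 log units; within the scatter). For compound 3 the expected value is 4500 nM, with an estimated range from 1400 nM to 15000 nM.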

Compound 3, half-maximal inhibitory concentration: 2650 nM
Compound 3: middle estimate off by 1.7-fold (0.23 log units), on the high side; low and high end bracket the measured number.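

In this assay, the change from 4-bromophenyl to 4-methylphenyl gives a 1.3-fold lower number from compound 2 to compound 3 (0.11 log units; within the scatter), so bromo and methyl cannot be told apart at this position, and the earlier step from iodo to bromo was not a matter of halogens alone. Among these three compounds iodo stands apart, with an at least 6.1-fold lower number from compound 1 to compound 3 (0.78 log units; beyond the scatter) for methyl in place of iodo. Compound 1 carries a limit of the assay, not a number, so that step has no exact size: the limit of > 16300 nM in this assay, at which 1 of the 3 values shown sits.

On these data alone, whether an amine, a methoxy group or a carboxylic acid at this position would match bromo and methyl or fall away like iodo stays open.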